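The source may report more compounds than this note shows. Statements on the series, on what has been measured and on what is new or still open speak of the compounds shown alone.

Of the compounds shown here, two built on one shared core have been tested in an ADME assay on HEK293 cells (Homo sapiens) for antiproliferative activity, read by MTT assay; on this read-out lower numbers stand for stronger inhibition and higher numbers for weaker inhibition. Compound 2 `Nc1c(C(=O)N/N=C/c2ccccc2)oc2nc(-c3ccccc3)cc(C(F)(F)F)c12` gives 70000 nM, and compound 1 `Nc1c(C(=O)N/N=C/c2ccc(Br)cc2)oc2nc(-c3cccs3)cc(C(F)(F)F)c12` gives 86000 nM; the two values sit within the scatter of each other, so neither stands apart. Compound 3 `Nc1c(C(=O)N/N=C/c2ccccc2)oc2nc(-c3cccs3)cc(C(F)(F)F)c12` is compound 2 with thiophen-2-yl in place of phenyl on an aromatic carbon. For the measured compounds named here, no measured pair shows this exact change, but compound 1 already carries thiophen-2-yl at that place and gives 86000 nM, so in this assay no step beyond the scatter is expected. Compound 3 is expected to give 75000 nM, within 35000 nM to 160000 nM, a step of a 1.1-fold higher number from compound 2 to compound 3 (0.03 log units; within the scatter).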

Compound 3, half-maximal inhibitory concentration: 72000 nM
Compound 3: middle estimate off by 1.0-fold (0.02 log units), on the high side; measured number inside the range.
By their numbers in this assay, from the lowest: compounds 2, 3 and 1 (each within the scatter of the next).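

In this assay the direct exchange of phenyl for thiophen-2-yl next to the ring nitrogen gives a 1.0-fold higher number from compound 2 to compound 3 (0.01 log units; within the scatter) and so shows that the two rings cannot be told apart on this carbon. Compound 3 also forms a second one-place pair, where hydrogen in place of bromo gives a 1.2-fold lower number from compound 1 to compound 3 (0.08 log units; within the scatter) and so the bromo makes no difference beyond the scatter when thiophen-2-yl is present. No further data explain these results. From the compounds shown here alone, whether an amine or a carboxylic acid on this carbon would give a step beyond the scatter remains open. The same holds for a methoxy group in place of the bromo.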